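A few compounds are considered here, and "the series" means these few. Any claim that something is new, unique, unknown or untested is made for them only; others in the source may bear on it.

Of the compounds shown here, three have so far been measured in an assay for inhibition of Alpha amylase (Homo sapiens), with a stated time of 10 min; a lower number here means a stronger inhibitor, a higher number a weaker inhibitor. Compound 1 `COc1ccc(Br)cc1-c1nc2cc(F)ccc2[nH]1` gives 2600 nM. Compound 2 `COc1cccc(-c2nc3cc(F)ccc3[nH]2)c1Cl` gives 2620 nM, and compound 3 `COc1cccc(-c2nc3cc(Cl)ccc3[nH]2)c1Cl` gives 2780 nM. The difference between the cores of compound 1 and compound 2 is not broken down here. Compound 2 and compound 3 differ in one place: chloro in place of fluoro on an aromatic carbon. That change gave a 1.1-fold higher number from compound 2 to compound 3 (0.03 log units; within the scatter), so the two numbers read as the same within the scatter of repeated measurements.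

Compound 4 `COc1ccc(Br)cc1-c1nc2cc(Cl)ccc2[nH]1` has not yet been measured in this assay. It stands to compound 1 as compound 3 stands to compound 2, through the same change: chloro in place of fluoro on an aromatic carbon. Because the earlier step of a 1.1-fold higher number from compound 2 to compound 3 (0.03 log units; within the scatter) stayed within the scatter, a similarly small step is expected here, a 1.1-fold higher number from compound 1 to compound 4 (0.03 log units; within the scatter). On that basis compound 4 is estimated at 2800 nM in this assay, with a likely range from 1500 nM to 5500 nM. Whether the number lands there is what the measurement of compound 4 will show.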

Compound 4, half-maximal inhibitory concentration: 2620 nM
Compound 4: middle estimate off by 1.1-fold (0.03 log units), on the high side; the range from low to high includes it.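

Replacing fluoro with chloro gave a 1.0-fold higher number from compound 1 to compound 4 (0.00 log units; within the scatter), so in this assay this change again leaves the two numbers reading as the same. Set beside the earlier case, the step carries from one core to the other with no difference that can be told apart from ordinary measurement noise: the same change on two cores in this assay, a 1.1-fold higher number (0.03 log units; within the scatter) from compound 2 to compound 3 and a 1.0-fold higher number (0.00 log units; within the scatter) from compound 1 to compound 4, 1.1-fold (0.02 log units) apart, within the scatter of two such steps. This shows that the swap makes no detectable difference on these two cores, at this one place and in this one assay, but it does not show that the same would hold on a third core, or that a change with a larger effect would transfer equally well.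

Only fluoro and chloro appear at this place on the aromatic ring, so a step that is itself too small to read is all that has been carried across the cores. Going by these compounds, what an amine or a carboxylic acid at the same aromatic carbon would do to the number, and whether such a step would also hold from one core to the other, stays open.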